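Fluoro on the core of compound 1

The compounds below may be only part of what the source reports. "The series", "measured", "known", "first", "only" and "open" are said of these compounds alone.

Values measured so far in a physicochemical assay for lipophilicity, using the shake flask method, in phosphate buffer, measured as octanol-water partition, with a stated time of 5 h, at pH 7.4; a higher number here means a more lipophilic compound, a lower number a more polar compound
- compound 1 `CN1CCN(c2cc(Nc3nccc(Nc4cccc(CO)c4)n3)cc(S(C)(=O)=O)c2)CC1` gives 1.75
- compound 2 `Cc1cnc(Nc2cc(N3CCNCC3)cc(S(C)(=O)=O)c2)nc1Nc1cccc(CO)c1` gives 1.09
- compound 3 `CC(=O)N1CCN(c2cc(Nc3ncc(C)c(Nc4cccc(CO)c4)n3)cc(S(C)(=O)=O)c2)CC1` gives 1.74

Compound 1 and compound 3 stand level within the scatter, and compound 2 lies lower than both, beyond the scatter.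

The change from compound 1 to compound 4 `CN1CCN(c2cc(Nc3ncc(F)c(Nc4cccc(CO)c4)n3)cc(S(C)(=O)=O)c2)CC1` is fluoro in place of hydrogen on an aromatic carbon and reads as fluoro in place of hydrogen on an aromatic carbon, ortho to a (3-(hydroxymethyl)phenyl)amino group.

For the measured compounds named here, the only measured single change in the set is a number 0.65 log units higher from compound 2 to compound 3 (beyond the scatter) and it stays modest. It concerns acetyl in place of hydrogen on an amine nitrogen in a ring, a different change at a different place, so it gives little guidance here. Going by the values given here, no measured step covers fluoro on this carbon.

The expected step is a number 0.10 log units higher from compound 1 to compound 4 (within the scatter) and it is expected to stay within the scatter, if anything upward. For compound 4 the estimated value is 1.85 with 1.5 as the expected lower end and 2.2 as the expected upper end.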

Compound 4, distribution coefficient: 1.84
For compound 4 the middle estimate is 0.01 log units above the measured one; the measured number falls inside the stated range.
By their numbers in this assay, from the lowest: compound 2; then compounds 3, 1 and 4 (each within the scatter of the next).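

In this assay, for the compounds shown here, fluoro in place of hydrogen on an aromatic carbon, ortho to a (3-(hydroxymethyl)phenyl)amino group, gives a number 0.09 log units higher from compound 1 to compound 4 (within the scatter), the first measured step at this position. On this evidence, the position takes fluoro without a step beyond the scatter, unlike a number 0.65 log units higher from compound 2 to compound 3 (beyond the scatter), which concerns a different change at a different place. No measured evidence bears on why the fluoro step has this size.

Chloro or a nitrile on this same carbon remains open, so a single fluoro step does not yet describe how this position responds to other groups. Also open, on these data alone, is whether fluoro gives a similar step when the amine nitrogen in the ring carries an acetyl group or hydrogen.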